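Fluoromethyl in place of hydrogen on compound 3

The compounds below may be only part of what the source reports. "The series", "measured", "known", "first", "only" and "open" are said of these compounds alone.

In a physicochemical assay for solubility (a lower number here means a less soluble compound, a higher number a more soluble compound), compound 3 `CNC(=O)c1cc(C(=O)NC)c2c(c1)[C@H](c1ccccc1)CO2` gives >= 130 ug/mL which is a limit and not a number. Compound 4 `CNC(=O)c1cc(C(=O)NC)c2c(c1)[C@H](c1ccccc1)[C@@H](CF)O2` differs from it by fluoromethyl in place of hydrogen on a saturated ring carbon and the change is fluoromethyl in place of hydrogen on a saturated ring carbon.

Compound 1 `CNC(=O)c1cc(C(N)=O)cc2c1O[C@H](CF)[C@H]2c1ccccc1` also carries fluoromethyl and gives >= 128 ug/mL which is likewise a limit and not a number. Compound 2 `CNC(=O)c1cc(C(=O)NCCC[C@H]2OC[C@H](N)CO2)cc2c1O[C@H](CF)[C@H]2c1ccccc1` carries the same group and gives 174 ug/mL as a true reading. Among the measured compounds shown here, the only measured step is a step that the limit leaves unreadable from compound 1 to compound 2 and it offers no size to carry over. For the measured compounds named here, no measured step isolates the fluoromethyl group itself.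

With compound 2 at 174 ug/mL despite bearing fluoromethyl, no step beyond the scatter is expected in this assay and no direction is favoured. The expected outcome is a step that the limit leaves unreadable from compound 3 to compound 4 as estimated from these few readings. Compound 4 is estimated at 140 ug/mL with an expected range from 70 ug/mL to 260 ug/mL as its likely span.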

Compound 4, solubility: >= 149 ug/mL
Compound 4: no number, only a limit (the forecaster's own chance of this, stated with the estimate: 55%); at least 1.0-fold (0.02 log units) between middle value and limit.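

In this assay, among the compounds shown here, the reading for compound 4 is a limit and not a number, and no step from compound 1, compound 2 or compound 3 to compound 4 can be read. The compounds shown leave open how far fluoromethyl in place of hydrogen on a saturated ring carbon moves the reading in this assay.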